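This account rests on a few compounds, and the source may have more. Where it says the series, first, only, none or still open, it means among the compounds named here.

Measured compounds:
compound 1 `C=CC(=O)Nc1cc(Nc2ncc3ncn(C4CCCC4)c3n2)c(OC)cc1N(C)CCN(C)C` gives 20900 nM in an ADME assay on HT-29 cells (Homo sapiens) for cytotoxicity, read by MTT assay, with a stated time of 72 h; on this read-out higher numbers stand for weaker inhibition and lower numbers for stronger inhibition;
compound 2 `C=CC(=O)Nc1cc(Nc2ncc3nc(Nc4ccccc4)n(C)c3n2)c(OC)cc1N(C)CCN(C)C` gives 8700 nM in this assay;
compound 3 `C=CC(=O)Nc1cc(Nc2ncc3nc(Nc4ccccc4)n(C(C)C)c3n2)c(OC)cc1N(C)CCN(C)C` gives 4720 nM in this assay.

Compound 3 has the lowest of these three numbers. Its nearest neighbour is compound 2, and the step of a 1.8-fold lower number from compound 2 to compound 3 (0.27 log units; within the scatter) stayed inside the scatter of repeated measurements, so the two cannot be told apart with confidence. Compound 1 sits further away, its number being well higher than that of compound 3; the two differ in more than one place, so their values are simply reported side by side.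

Compound 4 `C=CC(=O)Nc1cc(Nc2ncc3nc(Nc4ccccc4)n(C4CCCC4)c3n2)c(OC)cc1N(C)CCN(C)C` has not yet been measured. It differs from compound 3 by one change, (cyclopentyl in place of isopropyl on an aromatic nitrogen). Going by the values given here, the one measured step that enlarges the group on this same aromatic nitrogen, a 1.8-fold lower number from compound 2 to compound 3 (0.27 log units; within the scatter), was small. On that basis the step of a 1.3-fold lower number from compound 3 to compound 4 (0.13 log units; within the scatter) is expected to be small as well, perhaps a slight lowering but most likely within the scatter. The estimate for compound 4 in this assay is therefore 3500 nM, with a range from 1200 nM to 10000 nM.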

Compound 4, half-maximal inhibitory concentration: 11400 nM
Compound 4: middle estimate off by 3.3-fold (0.51 log units), on the low side, outside the stated range (above it).
By their numbers in this assay, from the lowest: compounds 3, 2, 4 and 1 (each within the scatter of the next, the first and the last beyond it).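

Going by these compounds alone, on this aromatic nitrogen, a larger group does not simply go with a lower number in this assay: cyclopentyl in place of isopropyl gives a 2.4-fold higher number from compound 3 to compound 4 (0.38 log units; beyond the scatter), the first step at this position to pass the scatter, and it runs upward. Cyclopentyl in place of methyl gives a 1.3-fold higher number from compound 2 to compound 4 (0.12 log units; within the scatter), so compound 2 and compound 4 cannot be told apart, and only isopropyl stands clear of cyclopentyl here. With cyclopentyl held on the nitrogen, anilino in place of hydrogen gives a 1.8-fold lower number from compound 1 to compound 4 (0.26 log units; within the scatter), so that change cannot be read as a real difference either, and no measurement at hand explains any of these steps.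

On these data alone, it remains open whether an open pentyl chain or a piperidine ring, which carries an amine, on this nitrogen would behave like cyclopentyl or like isopropyl. As far as these compounds go, how a chlorine on the anilino ring would shift these numbers also stays open.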